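The source may report more compounds than this note shows. Statements on the series, on what has been measured and on what is new or still open speak of the compounds shown alone.

Measured so far:
compound 1 `C=CCNC(=O)n1c(-c2ccc(OC)cc2)cc(=O)c2c(OC)cc(OC)cc21` gives 16000 nM
compound 2 `COc1ccc(-c2cc(=O)c3c(OC)cc(OC)cc3n2S(=O)(=O)c2c(F)c(F)c(F)c(F)c2F)cc1` gives 4100 nM

In a functional assay on SUP-B15 cells (Homo sapiens) for antiproliferative activity, with a stated time of 72 h (on this read-out higher numbers stand for an effect only at larger amounts of compound and lower numbers for an effect already at smaller amounts), compound 2 stands at the lower of the two numbers; compound 1 lies beyond the scatter above it. Compound 3 `COc1ccc(-c2cc(=O)c3c(OC)cc(OC)cc3n2S(=O)(=O)c2ccc(Cl)cc2)cc1` is not yet measured. It differs from compound 2 by 4-chlorophenyl in place of 2,3,4,5,6-pentafluorophenyl on a sulfonyl sulfur. Within the data shown here, no step of this kind is known among the measured compounds, so the direction cannot be read from them; a modest loss, or no change beyond the scatter, seems the likelier outcome. Compound 3 is therefore estimated at 6000 nM in this assay, within 1500 nM to 25000 nM, which would correspond to an expected step of a 1.5-fold higher number from compound 2 to compound 3 (0.17 log units; within the scatter).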

Compound 3, half-maximal effective concentration: > 34400 nM
Compound 3 ended at the assay's limit (the forecaster's own chance of this, stated with the estimate: 10%); at least 5.7-fold (0.75 log units) between middle value and limit.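

In this assay, among these compounds, compound 3 sits at a limit of the assay and has no exact value: the limit of > 34400 nM in this assay, at which 1 of the 3 values shown sits. On the sulfonyl sulfur, 4-chlorophenyl in place of 2,3,4,5,6-pentafluorophenyl gives an at least 8.3-fold higher number from compound 2 to compound 3 (0.92 log units; beyond the scatter), the first sign that the group at this position matters for this read-out. On the aromatic nitrogen, (4-chlorophenyl)sulfonyl in place of allylcarbamoyl gives an at least 2.1-fold higher number from compound 1 to compound 3 (0.33 log units; beyond the scatter), so a sulfonyl there does not by itself bring the lower number seen for compound 2.

From the compounds shown here alone, the full size of both steps stays open. So does how an unsubstituted phenyl or an amine on the sulfonyl sulfur would read.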